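Swapping the Sulfonyl Aryl Group: Fluorophenyl to Methylphenyl

A few compounds are considered here, and "the series" means these few. Any claim that something is new, unique, unknown or untested is made for them only; others in the source may bear on it.

Within the data shown here, compound 2 `CC1CCN(c2c(S(=O)(=O)c3cccc(F)c3)cnc3ccc(F)cc23)CC1` gives 76% in an assay on isolated protein for displacement of a labelled ligand from metabotropic glutamate receptor 5 (Homo sapiens), with a stated time of 60 min, tested at 1 uM (a higher number here means more inhibition at the concentration tested (going by the name of the read-out), a lower number less inhibition), the lower of the two numbers measured so far, though the gap to its neighbour is within the scatter. Compound 1 `Cc1cc(C)cc(S(=O)(=O)c2cnc3ccc(F)cc3c2N2CCC(C)CC2)c1` gives 83% in this assay; the step of a number 7 percentage points lower from compound 1 to compound 2 (within the scatter) came with 3-fluorophenyl in place of 3,5-dimethylphenyl on a sulfonyl sulfur. Compound 3 `Cc1ccc(S(=O)(=O)c2cnc3ccc(F)cc3c2N2CCC(C)CC2)cc1` differs from compound 2 by 4-methylphenyl in place of 3-fluorophenyl on a sulfonyl sulfur. Among the measured compounds shown here, only that one earlier step touches the same aryl group, and it lay within the scatter, so the expected step for compound 3 is a number 4 percentage points higher from compound 2 to compound 3 (within the scatter), with no clear direction. The estimate for compound 3 is 80%, from 65% to 92%.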

Compound 3, a percentage reported as inhibition, at one concentration (the size of the read-out at that concentration, not a potency): 91%
Compound 3: the middle estimate sits 11 percentage points below what was measured, within the range that was stated.
By their numbers in this assay, from the lowest: compounds 2, 1 and 3 (each within the scatter of the next, the first and the last beyond it).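

Among these compounds, the step to 4-methylphenyl is the first change on a sulfonyl sulfur to clear the scatter, with a number 15 percentage points higher from compound 2 to compound 3 (beyond the scatter) in this assay. The change from 3,5-dimethylphenyl, by contrast, gives a number 8 percentage points higher from compound 1 to compound 3 (within the scatter), so these two methyl-bearing aryl groups cannot be told apart here. No measurement at hand explains the difference from 3-fluorophenyl. As far as these compounds go, compound 2 and compound 3 differ in both the substituent and its place on the ring, so the effect of each remains open. 4-Fluorophenyl or 3-methylphenyl on the sulfonyl sulfur would help separate the two.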